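The source may hold more compounds than are shown below. What is called first, only, known or untested is meant among the compounds shown, and "the series" means these compounds.

Compound 1 `[N-]=[N+]=N[C@H]1C[C@H](n2cc(Br)c(=O)[nH]c2=O)O[C@@H]1CO` and compound 2 `CCc1cn([C@H]2CC[C@@H](CO)O2)c(=O)[nH]c1=O` were both tested in an ADME assay on Huh-7 cells (Homo sapiens) for cytotoxicity, read by XTT assay; on this read-out lower numbers stand for higher toxicity in this test and higher numbers for lower toxicity in this test. For compound 1 the assay reported only a limit, > 100 ug/mL. For compound 2 the assay likewise reported only a limit, > 100 ug/mL. Compound 2 therefore stands where every value shown stands, at the limit of > 100 ug/mL in this assay, at which 2 of the 2 values shown sit. Compound 3 `CCc1cn([C@H]2C[C@H](F)[C@@H](CO)O2)c(=O)[nH]c1=O` differs from compound 2 by fluoro in place of hydrogen on a saturated ring carbon. Among the compounds with values here, with no measured step of this kind to lean on, no change in this assay beyond the usual scatter is expected from this exchange. Compound 3 is accordingly expected to give about 100 ug/mL, within 50 ug/mL to 200 ug/mL, an expected step of a number no higher from compound 2 to compound 3 (the limit leaves the size open).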

Compound 3, half-maximal cytotoxic concentration: > 100 ug/mL
Compound 3: only a limit was reported; the forecaster's own chance of this, stated with the estimate: 85%; the middle value sits exactly at the limit.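

Within the data shown here, compound 2 and compound 3 each carry only a limit in this assay, so no step between them can be read. Whether fluoro in place of hydrogen changes toxicity in this test stays open, as does any ranking of the compounds shown, which all share one limit: the limit of > 100 ug/mL in this assay, at which 3 of the 3 values shown sit.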